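Two Inverted Ring Stereocentres in Compound 2

The source may hold more compounds than are shown below. What is called first, only, known or untested is meant among the compounds shown, and "the series" means these compounds.

In a functional assay on HeLa cells (Homo sapiens) for cytotoxicity, read by WST assay, with a stated time of 48 h (a higher number here means a weaker inhibitor, a lower number a stronger inhibitor), compound 1 (`COc1ccc(CCC[C@H]2C[C@@H]([C@@H](O)c3ccc(OC)c(OC)c3)CO[C@@H]2c2ccc(OC)c(OC)c2)cc1OC`) gives 37700 nM while compound 2 (`COc1ccc(/C=C/C[C@@H]2C[C@@H]([C@@H](O)c3ccc(OC)c(OC)c3)CO[C@H]2c2ccc(OC)c(OC)c2)cc1`) gives 17100 nM as the lower of the two numbers, which makes it the stronger of the pair by a gap just beyond the usual scatter. Compound 3 (`COc1ccc(/C=C/C[C@H]2C[C@@H]([C@@H](O)c3ccc(OC)c(OC)c3)CO[C@@H]2c2ccc(OC)c(OC)c2)cc1`) has not yet been measured. It has the same atoms and bonds as compound 2 and differs only in configuration as drawn (the two compounds have the same atoms and bonds and differ only in configuration as drawn: 2 of 5 stereo elements differ; a stereocentre at a saturated ring carbon is drawn R in compound 2 and S in compound 3; a stereocentre at a saturated ring carbon is drawn R in compound 2 and S in compound 3), with two stereocentres at saturated ring carbons drawn R in compound 2 and S in compound 3. Within the data shown here, no measured pair isolates a change of this kind, so the data give no direct guide to its size or direction. The expected 1.2-fold higher number from compound 2 to compound 3 (0.07 log units; within the scatter) stays within the scatter, with only a slight lean towards a higher number. Compound 3 is estimated at 20000 nM (range 7000 nM to 55000 nM).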

Compound 3, half-maximal inhibitory concentration: 12200 nM
For compound 3 the middle estimate is 1.6-fold (0.21 log units) above the measured one; low and high end bracket the measured number.
By their numbers in this assay, from the lowest: compounds 3 and 2 (each within the scatter of the next); then compound 1.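

Inverting the two saturated ring stereocentres gives a 1.4-fold lower number from compound 2 to compound 3 (0.15 log units; within the scatter), so in this assay this pair shows that these two centres, changed together, do not move the number outside the scatter, and compound 2 and compound 3 cannot be ranked. The comparison tests stereochemistry alone, since the pair is separated by nothing else: the fact that compounds 2 and 3 differ only in the configuration as drawn. Compound 3 also gives a listed side-chain step, with 2-(4-methoxyphenyl)ethenyl in place of 2-(3,4-dimethoxyphenyl)ethyl, of a 3.1-fold lower number from compound 1 to compound 3 (0.49 log units; beyond the scatter), a modest step beyond the scatter.

That step changes the chain and the methoxy count together, so the compounds shown cannot say which of the two matters. From the compounds shown here alone, how a side chain ending in an amine or a carboxylic acid would behave also stays open, as does the effect of inverting either ring centre alone.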